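The compounds below may be only part of what the source reports. "The series", "measured", "known", "first", "only" and "open" are said of these compounds alone.

Compound 2 `Cc1ccc([Se]CC(C)N)cc1` gives the lowest of the two numbers measured in an assay on isolated protein for inhibition of Amine oxidase [flavin-containing] A (Homo sapiens), read by fluorescence and spectrophotometry (on this read-out lower numbers stand for stronger inhibition and higher numbers for weaker inhibition), namely 2030 nM; compound 1 `CC(N)C[Se]c1ccc(F)cc1` gives 10500 nM, and the step of a 5.2-fold lower number from compound 1 to compound 2 (0.71 log units; beyond the scatter) lies beyond the scatter. Compound 3 `CC(N)C[Se]c1ccc(N(C)C)cc1` differs from compound 2 by dimethylamino in place of methyl on an aromatic carbon. Among the compounds with values here, no measured step covers a dimethylamino group, so the only guide is that one change at this aromatic carbon, from compound 1 to compound 2, shifted the number modestly. A step of similar or smaller size is therefore expected, a 1.4-fold lower number from compound 2 to compound 3 (0.13 log units; within the scatter), direction uncertain. Compound 3 is estimated at 1500 nM, between 300 nM and 6000 nM.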

Compound 3, half-maximal inhibitory concentration: 7150 nM
Beside the measured number, compound 3's estimate is 4.8-fold (0.68 log units) below it; measured number outside the range, above it.
By their numbers in this assay, from the lowest: compound 2; then compounds 3 and 1 (each within the scatter of the next).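

In this assay, dimethylamino in place of methyl gives a 3.5-fold higher number from compound 2 to compound 3 (0.55 log units; beyond the scatter), so a change at this aromatic carbon can also raise the number, and the gain seen with methyl does not carry over to a larger group. Dimethylamino in place of fluoro gives a 1.5-fold lower number from compound 1 to compound 3 (0.17 log units; within the scatter), which stays within the scatter, leaving methyl as the only one of the three groups that stands apart. Nothing shown explains this difference. Going by these compounds, whether ethyl, chlorine or methoxy at this carbon would match methyl remains open, as does the effect of a bare hydrogen there.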